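Chain substituent exchange on the shared core

The compounds below may be only part of what the source reports. "The series", "measured", "known", "first", "only" and "open" are said of these compounds alone.

Compound 1 `CCCCCCCCCCCCCCCCCCOCC(CCCC)NC(C)=O` and compound 2 `CCCCCCCCCCCCCCCCCCOCC(CCS(=O)(=O)c1ccc(C)cc1)NC(C)=O` differ only in the group on a saturated chain carbon, three bonds along the chain from an amide-type nitrogen. In an assay for inhibition of putative inactive group IIC secretory phospholipase A2 (Homo sapiens) (on this read-out higher numbers stand for weaker inhibition and lower numbers for stronger inhibition), compound 1 gives 60000 nM. In this assay, among the compounds with values here, compound 2 gives 50000 nM, the lowest of the two numbers so far, with compound 1 its nearest neighbour; the step of a 1.2-fold lower number from compound 1 to compound 2 (0.08 log units; within the scatter) lies within the scatter. Compound 3 `CCCCCCCCCCCCCCCCCCOCC(CCc1nnn[nH]1)NC(C)=O` is not yet measured. Its change from compound 2 is 1H-tetrazol-5-yl in place of (4-methylphenyl)sulfonyl on a saturated chain carbon, three bonds along the chain from an amide-type nitrogen. Within the data shown here, no measured step covers this exchange; the only step at this place, a 1.2-fold lower number from compound 1 to compound 2 (0.08 log units; within the scatter), was within the scatter. On that basis compound 3 is expected to show little movement in this assay, a step of about no change at the digits printed from compound 2 to compound 3 (within the scatter), in no clear direction. The estimate for compound 3 is 50000 nM, with a range from 15000 nM to 150000 nM.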

Compound 3, half-maximal inhibitory concentration: 570 nM
Compound 3: middle estimate off by 88-fold (1.94 log units), on the high side, outside the stated range (below it).
By their numbers in this assay, from the lowest: compound 3; then compounds 2 and 1 (each within the scatter of the next).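

At this position, on a saturated chain carbon, three bonds along the chain from an amide-type nitrogen, the choice of group can strongly change the read-out in this assay. Replacing (4-methylphenyl)sulfonyl with 1H-tetrazol-5-yl gives an 88-fold lower number from compound 2 to compound 3 (1.94 log units; beyond the scatter), and replacing ethyl with the same group gives a 110-fold lower number from compound 1 to compound 3 (2.02 log units; beyond the scatter), so the position is not insensitive, as the first exchange alone had suggested. Nothing available explains why this group stands apart from the other two.

The compounds shown leave open whether the 1H-tetrazol-5-yl ring itself is required, or whether a carboxylic acid at the same place would give a similarly low number. Also open, on these data alone, is how a longer chain between the shared core and the ring would affect the read-out.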